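The source may hold more compounds than are shown below. What is called first, only, known or untested is meant among the compounds shown, and "the series" means these compounds.

Working notes on the series. In a functional assay on MCF7 cells (Homo sapiens) for cytotoxicity, read by MTT assay (a lower number here means that less compound is needed, a higher number that more compound is needed for the effect), compound 1 (`C=C1CC/C=C(\C)[C@H](OC(C)=O)[C@@H]2OC(=O)C(=C)[C@H]2C[C@H](O)[C@@]2(C)CC[C@@H]1O2`) gives 3.2 ug/mL and compound 2 (`C=C1C(=O)O[C@H]2C/C(C)=C/CCC(=C)[C@H]3CC[C@@](C)(O3)[C@@H](O)C[C@H]12`) gives 2 ug/mL as its reading. Among the compounds with values here, these two values lie within the usual scatter of each other, so compound 2 stands level with compound 1, the only other number available so far.

Compound 3 (`C=C1CC/C=C(\C)C[C@@H]2OC(=O)C(=C)[C@H]2C[C@H](O)[C@@]2(C)CC[C@@H]1O2`) has not yet been measured. Its relation to compound 2 is purely one of drawn configuration: the two compounds have the same atoms and bonds and differ only in configuration as drawn: 1 of 6 stereo elements differ; a stereocentre at a saturated ring carbon is drawn R in compound 2 and S in compound 3 (a stereocentre at a saturated ring carbon is drawn R in compound 2 and S in compound 3).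

Within the data shown here, no pair of measured compounds differs in one place, so the data give no direct size for a change of this kind. In this assay no step beyond the scatter is expected, with a slight lean towards a higher number. The estimated change is a 1.5-fold higher number from compound 2 to compound 3 (0.18 log units; within the scatter) and stays within the scatter. The range is kept wide on the upper side, since the effect of this configuration change has not been measured in the series. For compound 3 the expected value is 3 ug/mL with an estimated range of 1.2 ug/mL to 8 ug/mL around it.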

Compound 3, concentration for half-maximal effect: 4.1 ug/mL
Compound 3: the middle estimate sits 1.4-fold (0.14 log units) below what was measured, and the stated range covers the measured number.
By their numbers in this assay, from the lowest: compounds 2, 1 and 3 (each within the scatter of the next, the first and the last beyond it).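

In this assay, the series now has its first measured size for a change of drawn configuration alone at a saturated ring carbon (a 2.1-fold higher number from compound 2 to compound 3 (0.31 log units; beyond the scatter)), a modest step that lies beyond the scatter. The step can be assigned to configuration because nothing else separates the two structures: the fact that compounds 2 and 3 differ only in the configuration as drawn. Within the data shown here, the second step (a 1.3-fold higher number from compound 1 to compound 3 (0.11 log units; within the scatter)) gives the first reading for hydrogen in place of acetoxy on a saturated ring carbon; it stays within the scatter, so the two compounds stand level in this assay and this exchange shows no measurable effect.

The compounds shown leave open whether the configuration step keeps its size when acetoxy is present, and a single pair cannot show whether other stereo elements of the shared core matter to the same degree. They also leave open how that saturated ring carbon responds to groups other than hydrogen and acetoxy, such as a free hydroxyl, a longer ester like butanoyloxy, or an amine.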